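Moving a chloromethyl arm and swapping chloro for amino

The compounds below may be only part of what the source reports. "The series", "measured", "known", "first", "only" and "open" are said of these compounds alone.

Three compounds share a two-ring core carrying a chloromethyl-bearing benzyl group. Compound 1 `Nc1nc(Cl)c2ncn(Cc3ccc(CCl)cc3)c2n1`, compound 3 `ClCc1ccc(Cn2cnc3c(Cl)nc(Cl)nc32)cc1` and compound 2 `ClCc1cccc(Cn2cnc3c(Cl)nc(Cl)nc32)c1` were tested in a functional assay on SN12C cells (Homo sapiens) for cytotoxicity, read by sulforhodamine B assay, with a stated time of 48 h; a lower number here means that less compound is tolerated, a higher number that more compound is tolerated. Compound 1 gives 60300 nM, compound 3 gives 51300 nM and compound 2 gives 11800 nM. Compounds 3 and 1 differ in one place: amino in place of chloro on an aromatic carbon. That change made the step of a 1.2-fold higher number from compound 3 to compound 1 (0.07 log units; within the scatter), so the two values show no difference that can be trusted. Compounds 2 and 3 are built from the same atoms joined differently; the difference between the two cores is not broken down here, and the values only show that compound 2 is tolerated less than compound 3, beyond the usual scatter.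

Compound 4 `Nc1nc(Cl)c2ncn(Cc3cccc(CCl)c3)c2n1` has not been measured. It stands to compound 2 as compound 1 stands to compound 3, with the same change: amino in place of chloro on an aromatic carbon. The surroundings of the exchanged group read the same in both pairs, so this is the same change seen once already. Because the earlier step was a 1.2-fold higher number from compound 3 to compound 1 (0.07 log units; within the scatter), the step from compound 2 to compound 4 is expected to be similar in size, a 1.2-fold higher number from compound 2 to compound 4 (0.07 log units; within the scatter). Compound 4 is therefore estimated to give about 14000 nM in this assay, most likely between 6000 nM and 33000 nM. Among the compounds with values here, the rest is uncertain, since only one earlier example of the change exists and the two cores differ in a way not counted here.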

Compound 4, concentration lethal to 50% of the cells: 39800 nM
The estimate for compound 4 lay 2.8-fold (0.45 log units) below the measured number; the measured number lies above the stated range.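

In this assay, amino in place of chloro on the aromatic carbon gives a 3.4-fold higher number from compound 2 to compound 4 (0.53 log units; beyond the scatter), so more of the compound is tolerated after this change on the core of compound 2. The same change does not carry over with the same size to the other core, where the chloromethyl arm is attached differently on the benzyl group: the same change on two cores in this assay, a 1.2-fold higher number (0.07 log units; within the scatter) from compound 3 to compound 1 and a 3.4-fold higher number (0.53 log units; beyond the scatter) from compound 2 to compound 4, 2.9-fold (0.46 log units) apart, beyond the scatter of two such steps. This shows that a step seen on one core is a poor guide to its size on the other in this series, but two pairs cannot show why the steps differ or predict the step on any further core.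

The compounds shown leave open whether the gap between the two steps follows from where the chloromethyl arm is attached or would also appear with a hydroxymethyl or a plain methyl group in its place. They also leave open how this assay would respond on either core if a methylamino or a methoxy group took the place of the amino group on that same aromatic carbon.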